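Piperazine amide variant of compound 1

The compounds below may be only part of what the source reports. "The series", "measured", "known", "first", "only" and "open" are said of these compounds alone.

Compound 1 `CC(C)(C)c1ccc(C(=O)N2CCC3(CC2)C(=O)N(CC(=O)N2CCCCC2CCO)CN3c2ccccc2)cc1` gives 6100 nM in an assay on HEK293 cells for displacement of a labelled ligand from NPC1-like intracellular cholesterol transporter 1 (Homo sapiens) (on this read-out higher numbers stand for weaker inhibition and lower numbers for stronger inhibition), the highest of the three numbers shown. Compound 3 `CC(C)(C)OC(=O)NC1CCCN(C(=O)CN2CN(c3ccccc3)C3(CCN(C(=O)c4ccc(C5CCCCC5)cc4)CC3)C2=O)C1` gives 4400 nM in this assay, which sits within the scatter of compound 1. Compound 2 `O=C(CN1CN(c2ccccc2)C2(CCN(C(=O)c3ccc(C4CCCCC4)cc3)CC2)C1=O)NCCO` gives 2000 nM in this assay, a gap from compound 1 that lies beyond the scatter. Compounds 2 and 3 each differ from compound 1 in more than one place, so no single change is isolated among the measured compounds. Compound 4 `CC(C)(C)c1ccc(C(=O)N2CCC3(CC2)C(=O)N(CC(=O)N2CCNCC2)CN3c2ccccc2)cc1` awaits measurement. Its change from compound 1: piperazin-1-yl in place of 2-(2-hydroxyethyl)piperidin-1-yl on a carbonyl carbon. Among the measured compounds shown here, no measured pair shows this change, so the step from compound 1 is expected to stay within the scatter, estimated as a 1.4-fold lower number from compound 1 to compound 4 (0.13 log units; within the scatter). Compound 4 is expected to give 4500 nM in this assay, within a range from 1500 nM to 13000 nM.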

Compound 4, half-maximal inhibitory concentration: 22000 nM
Compound 4: the middle estimate sits 4.9-fold (0.69 log units) below what was measured; the measured number lies above the stated range.
By their numbers in this assay, from the lowest: compound 2; then compounds 3 and 1 (each within the scatter of the next); then compound 4.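

The group on the carbonyl carbon is a position that responds to a single change: in this assay, piperazin-1-yl in place of 2-(2-hydroxyethyl)piperidin-1-yl gives a 3.6-fold higher number from compound 1 to compound 4 (0.56 log units; beyond the scatter), weaker inhibition beyond the scatter. The hydrogen-bond donor and acceptor counts stay the same across this change, while the heavy atoms fall from 9 to 6. No measurement in hand bears on the reason for this loss.

Still open, as far as these compounds go, is whether the loss goes with the second ring nitrogen or with the missing 2-hydroxyethyl chain. Plain piperidin-1-yl on the same carbonyl carbon would separate the two.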